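The source may report more compounds than this note shows. Statements on the series, on what has been measured and on what is new or still open speak of the compounds shown alone.

Compound 1, with the structure `C=C1C[C@]23C[C@@]1(O)CC[C@@H]2c1cccc(C)c1[C@@H]3Cn1cc(-c2ccc(C)cc2)nn1`, is one of two compounds for which a reading exists in a functional assay on HL-60 cells (Homo sapiens) for cytotoxicity, read by MTT assay, with a stated time of 4 days; on this read-out lower numbers stand for stronger inhibition and higher numbers for weaker inhibition. In this assay compound 1 gives > 20000 nM, which is a limit of the assay and not a number, so for compound 1 only a limit is known. Compound 2, `Cc1ccc(S(=O)(=O)Oc2ccc3c(c2C)[C@H](Cn2cc(-c4ccc(Br)cc4)nn2)[C@@]24CC(=O)[C@@](C)(CC[C@@H]32)C4)cc1`, is the other compound with a reading. In this assay compound 2 also gives > 20000 nM, again a limit rather than a number. Going by the values given here, both readings sit at the limit of > 20000 nM in this assay, at which 2 of the 2 values shown sit, and no step between two compounds with real numbers is available, so no change has yet been measured. The compound to be measured next is compound 3, `C=C1C[C@]23C[C@@]1(O)CC[C@@H]2c1cccc(C)c1[C@@H]3Cn1cc(-c2ccccn2)nn1`. It differs from compound 1 in one place: pyridin-2-yl in place of 4-methylphenyl on an aromatic carbon. With compound 1 at a limit, the step that the limit leaves unreadable from compound 1 to compound 3 is expected to be none beyond the scatter. Compound 3 is therefore estimated to give 25000 nM in this assay, within a range from 8000 nM to 60000 nM, most likely reported again only as a limit.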

Compound 3, half-maximal inhibitory concentration: > 20000 nM
Compound 3 ended at the assay's limit (the forecaster's own chance of this, stated with the estimate: 75%); the middle value is on the limit's open side.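

Compound 3 and compound 1 both end at a limit of this assay, not at a number, so no step can be read between them: the limit of > 20000 nM in this assay, at which 3 of the 3 values shown sit.

The compounds shown leave open whether pyridin-2-yl in place of 4-methylphenyl changes the reading at all, and what reading any compound of this series would give as a real number.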